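The source may report more compounds than this note shows. Statements on the series, on what has been measured and on what is new or still open speak of the compounds shown alone.

Three compounds have been measured in an assay on CHO cells for displacement of a labelled ligand from C-X-C chemokine receptor type 3 (Homo sapiens), with a stated time of 60 min; on this read-out higher numbers stand for weaker inhibition and lower numbers for stronger inhibition:

compound 1, `Cc1cc(CN(C2CCC2)C(CC(=O)O)c2ccc(Cl)cc2)ccc1OCCn1c(=O)ccn(C)c1=O`, 95 nM
compound 2, `COc1cc(CN(C2CCC2)C(CC(=O)O)c2ccc(Cl)cc2)ccc1OCCn1c(=O)ccn(C)c1=O`, 152 nM
compound 3, `COc1cc(CN(CC(C)C)C(CC(=O)O)c2ccc(Cl)c(F)c2)ccc1OCCN1C(=O)CCC1=O`, 70 nM

Of these, compound 3 has the lowest number; its gap to compound 1 lies within the usual scatter, while its gap to compound 2 lies beyond it. Compound 4, `Cc1cc(CN(CC(C)C)C(CC(=O)O)c2ccc(Cl)c(F)c2)ccc1OCCN1C(=O)CCC1=O`, has not yet been measured in this assay. It differs from compound 3 in a single place: methyl in place of methoxy on an aromatic carbon. The same kind of change links compound 2 to compound 1: methyl in place of methoxy on an aromatic carbon. The surroundings are not identical: in compound 3 the changed carbon stands ortho to a 2-(2,5-dioxopyrrolidin-1-yl)ethoxy group and meta to a large group, whereas in compound 2 it stands ortho to a large group and meta to a large group. The difference between the core of compound 2 and the core of compound 3 is not broken down here. The earlier step gave a 1.6-fold lower number from compound 2 to compound 1 (0.20 log units; within the scatter). For compound 4 the expected step is a 1.4-fold lower number from compound 3 to compound 4 (0.15 log units; within the scatter), resting on compound 3 at 70 nM and on that earlier step. Compound 4 is therefore estimated at 50 nM, expected between 25 nM and 100 nM.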

Compound 4, half-maximal inhibitory concentration: 47 nM
Compound 4: the middle estimate sits 1.1-fold (0.03 log units) above what was measured, and the stated range covers the measured number.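

On the core of compound 3, methyl in place of methoxy gives (a 1.5-fold lower number from compound 3 to compound 4 (0.17 log units; within the scatter)) in this assay, and the question is whether this matches the same change on the core of compound 2. The two steps agree: the same change on two cores in this assay, a 1.6-fold lower number (0.20 log units; within the scatter) from compound 2 to compound 1 and a 1.5-fold lower number (0.17 log units; within the scatter) from compound 3 to compound 4, 1.1-fold (0.03 log units) apart, within the scatter of two such steps. So in this small set the change carries across both cores with no detectable difference, but each step on its own lies within the scatter, so neither shows that the swap really moves the number, and two cores say nothing about any other core in the series.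

The compounds shown leave open how an ethoxy group, a chlorine atom or a plain hydrogen on the same aromatic carbon would compare with methyl and methoxy. They also leave open whether the step would hold on a core in which an amide or a tetrazole stands in place of the carboxylic acid.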